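A few compounds are considered here, and "the series" means these few. Any claim that something is new, unique, unknown or untested is made for them only; others in the source may bear on it.

Measured so far:
- compound 1, `ClCc1ccc(Cn2cnc3c(Cl)ncnc32)cc1`: 3380 nM
- compound 2, `ClCc1ccccc1Cn1cnc2c(Cl)nc(Cl)nc21`: 1820 nM
- compound 3, `Nc1nc(Cl)c2ncn(Cc3ccc(CCl)cc3)c2n1`: 15100 nM

These three compounds were tested in a functional assay on SK-OV-3 cells (Homo sapiens) for cytotoxicity, read by sulforhodamine B assay, with a stated time of 48 h; a lower number here means a stronger inhibitor of growth, a higher number a weaker inhibitor of growth. Compound 2 stands at the lowest of the three numbers; compound 1 lies within the scatter of it, while compound 3 lies well beyond, at the high end. Among the measured compounds shown here, the only single-point change among the measured compounds is the one from compound 1 to compound 3, where an amino group replaces a hydrogen on an aromatic carbon and the number rises: a 4.5-fold higher number from compound 1 to compound 3 (0.65 log units; beyond the scatter).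

Compound 4, `Nc1nc(Cl)c2ncn(Cc3ccccc3CCl)c2n1`, is not yet measured. Compared with compound 2 it carries amino in place of chloro on an aromatic carbon, that is, an amino group in place of a chloro group on an aromatic carbon between two ring nitrogen atoms of the shared core. For the measured compounds named here, the one relevant comparison, the step from compound 1 to compound 3, also introduced an amino group on this core and moved the number up by a modest amount. The same direction is therefore expected here: a higher number, of roughly similar size, as the step of a 4.0-fold higher number from compound 2 to compound 4 (0.60 log units; beyond the scatter). Compound 4 is expected to give about 7300 nM, within a range from 2500 nM to 20000 nM.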

Compound 4, concentration for 50% growth inhibition: 15500 nM
Estimate against measurement, compound 4: 2.1-fold (0.33 log units) below, within the range that was stated.
By their numbers in this assay, from the lowest: compounds 2 and 1 (each within the scatter of the next); then compounds 3 and 4 (each within the scatter of the next).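

In this assay, putting amino in place of chloro on the aromatic carbon between two ring nitrogen atoms gives an 8.5-fold higher number from compound 2 to compound 4 (0.93 log units; beyond the scatter) and so shows that the number also rises when amino replaces a chloro group, not only a hydrogen. The earlier change, with a 4.5-fold higher number from compound 1 to compound 3 (0.65 log units; beyond the scatter) on introducing amino in place of hydrogen, went in the same direction, so the two pairs agree. Compound 3 and compound 4, the two compounds carrying amino, lie within the scatter of each other.

As far as these compounds go, whether a methylamino or a methoxy group on this carbon would behave like amino remains open. Nothing measured here explains why the number rises with amino on this carbon.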